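Shortening the ether on the shared core: compound 4

The compounds below may be only part of what the source reports. "The series", "measured", "known", "first", "only" and "open" are said of these compounds alone.

Among the measured compounds shown here, compound 1 `CCOc1ccc2oc(/C=C/[S+](C)[O-])cc(=O)c2c1` gives 4900 nM in a functional assay on DLD-1 cells (Homo sapiens) for cytotoxicity, with a stated time of 48 h (on this read-out lower numbers stand for stronger inhibition and higher numbers for weaker inhibition), and carries the lowest of the three numbers so far, though compound 3 `CC(C)CC(=O)Oc1ccc2oc(/C=C/[S+](C)[O-])cc(=O)c2c1` at 6100 nM and compound 2 `CCCC(=O)Oc1ccc2oc(/C=C/[S+](C)[O-])cc(=O)c2c1` at 8700 nM both sit within the scatter of it. The step of a 1.8-fold higher number from compound 1 to compound 2 (0.25 log units; within the scatter) and the step of a 1.2-fold higher number from compound 1 to compound 3 (0.10 log units; within the scatter) each alter what sits on the oxygen on the aromatic ring without moving the number beyond the scatter. Compound 4 `COc1ccc2oc(/C=C/[S+](C)[O-])cc(=O)c2c1` differs from compound 1 by hydrogen in place of methyl on a saturated chain carbon bound to an oxygen on an aromatic ring, a change at the same oxygen. Because those steps stayed within the scatter, no step beyond it is expected for compound 4 in this assay. For compound 4 the expected value is 5000 nM, with a range from 2500 nM to 10000 nM, an expected step of a 1.0-fold higher number from compound 1 to compound 4 (0.01 log units; within the scatter).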

Compound 4, half-maximal inhibitory concentration: 5700 nM
Compound 4: the middle estimate sits 1.1-fold (0.06 log units) below what was measured, and the stated range covers the measured number.
By their numbers in this assay, from the lowest: compounds 1, 4, 3 and 2 (each within the scatter of the next).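

Shortening ethoxy to methoxy leaves the number within the scatter, with a 1.2-fold higher number from compound 1 to compound 4 (0.07 log units; within the scatter), and swapping either ester for methoxy does the same, with a 1.1-fold lower number from compound 3 to compound 4 (0.03 log units; within the scatter) and a 1.5-fold lower number from compound 2 to compound 4 (0.18 log units; within the scatter). In this assay, the four groups on this oxygen therefore cannot be told apart, and this now includes the shortest ether shown. Adding a methyl also gives a matching small step on two different chains: the same change on two cores in this assay, a 1.4-fold lower number (0.15 log units; within the scatter) from compound 2 to compound 3 and a 1.2-fold lower number (0.07 log units; within the scatter) from compound 4 to compound 1, 1.2-fold (0.09 log units) apart, within the scatter of two such steps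

Still open, going by these compounds, is whether a free hydroxyl, a carboxylic acid or an amine-bearing chain on this oxygen would give a step beyond the scatter.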